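The source may report more compounds than this note shows. Statements on the series, on what has been measured and on what is new or still open speak of the compounds shown alone.

Measured compounds:
compound 1 `CCNC1=NS(=O)(=O)c2cc(Br)c(Cl)cc2N1`, 3300 nM
compound 2 `CC(C)NC1=NS(=O)(=O)c2cc(Br)c(Cl)cc2N1`, 5600 nM
compound 3 `CCNC1=NS(=O)(=O)c2cc(F)c(Cl)cc2N1`, 42400 nM

All three were run in a functional assay (aorta) with Rattus norvegicus as the target, with a stated time of 90 min, at 37 degrees C; on this read-out higher numbers stand for an effect only at larger amounts of compound and lower numbers for an effect already at smaller amounts. Compound 4 `CCCNC1=NS(=O)(=O)c2cc(F)c(Cl)cc2N1` is not yet measured.

Compound 2 differs from compound 1 by methyl in place of hydrogen on a saturated chain carbon bound to an amine nitrogen and a saturated chain carbon; this gave a 1.7-fold higher number from compound 1 to compound 2 (0.23 log units; within the scatter). Compound 3 differs from compound 1 in the core, by fluoro in place of bromo on an aromatic carbon, which gave a 13-fold higher number from compound 1 to compound 3 (1.11 log units; beyond the scatter), and compound 3 therefore gives the highest number of the three.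

Compound 4 differs from compound 3 by methyl in place of hydrogen on a saturated chain carbon, two bonds along the chain from an amine nitrogen. This is the same kind of change as between compound 1 and compound 2, not the same: there the methyl enters on a saturated chain carbon bound to an amine nitrogen and a saturated chain carbon, here on a saturated chain carbon, two bonds along the chain from an amine nitrogen. A step of similar size, a 1.3-fold higher number from compound 3 to compound 4 (0.11 log units; within the scatter), is expected in this assay, because the earlier step of a 1.7-fold higher number from compound 1 to compound 2 (0.23 log units; within the scatter) was small. Compound 4 is thus expected to give 55000 nM, estimated between 22000 nM and 140000 nM.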

Compound 4, half-maximal effective concentration: 45300 nM
For compound 4 the middle estimate is 1.2-fold (0.08 log units) above the measured one, and the stated range covers the measured number.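

In this assay the added methyl leaves the number within the scatter on the core of compound 3, with a 1.1-fold higher number from compound 3 to compound 4 (0.03 log units; within the scatter), and the step on the core of compound 1 agrees with it: the same change on two cores in this assay, a 1.7-fold higher number (0.23 log units; within the scatter) from compound 1 to compound 2 and a 1.1-fold higher number (0.03 log units; within the scatter) from compound 3 to compound 4, 1.6-fold (0.20 log units) apart, within the scatter of two such steps. Within these two pairs, then, a small methyl step carries from the bromo core to the fluoro core, even though fluoro in place of bromo itself gives a 13-fold higher number from compound 1 to compound 3 (1.11 log units; beyond the scatter). For the compounds shown here, this does not show that the change transfers in general: only two pairs are at hand, and the methyl enters at different places, on a saturated chain carbon bound to an amine nitrogen and a saturated chain carbon in compound 2 but two bonds along the chain from an amine nitrogen in compound 4, so place and core are confounded.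

A propylamino chain on the core of compound 1 and an isopropylamino chain on the core of compound 3 would separate these two factors. Going by these compounds, a longer chain such as butylamino, a cyclopropyl group on the amine nitrogen and a carboxylic acid at the chain end also remain open.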